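Tracheal series: methyl on the aryl group of compound 2

The source may report more compounds than this note shows. Statements on the series, on what has been measured and on what is new or still open speak of the compounds shown alone.

Within the data shown here, compound 1 `CO[C@@]12CCN(C)C[C@H]1[C@H](c1ccccc1)C(C#N)=C(N)O2` and compound 2 `CO[C@@]12CCN(Cc3ccccc3)C[C@H]1[C@H](c1ccccc1)C(C#N)=C(N)O2` are the two members measured so far in a functional assay on trachea (Cavia porcellus); on this read-out lower numbers stand for stronger inhibition and higher numbers for weaker inhibition. Compound 1 gives 19800 nM and compound 2 gives 22600 nM. The step between them, a 1.1-fold higher number from compound 1 to compound 2 (0.06 log units; within the scatter), leaves compound 2 at the higher of the two numbers, yet the two values sit within the scatter of each other, so neither compound is set apart from the other.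

Compound 3 `CO[C@@]12CCN(Cc3ccccc3)C[C@H]1[C@H](c1ccc(C)cc1)C(C#N)=C(N)O2` is the next compound and differs from compound 2 in one place: methyl in place of hydrogen on an aromatic carbon. Among the measured compounds shown here, no measured step bears directly on this change. For the measured compounds named here, the only step in hand, a 1.1-fold higher number from compound 1 to compound 2 (0.06 log units; within the scatter), concerns phenyl in place of hydrogen on a saturated chain carbon bound to an amine nitrogen in a ring, a different site and a different group, and it stayed within the scatter. With nothing pointing either way, the change is expected to leave the number about where it stands. The estimated step for compound 3 is a 1.0-fold lower number from compound 2 to compound 3 (0.01 log units; within the scatter) in this assay. The estimate for compound 3 is 22000 nM, in a range from 8000 nM to 60000 nM.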

Compound 3, half-maximal inhibitory concentration: 27100 nM
The estimate for compound 3 lay 1.2-fold (0.09 log units) below the measured number, within the range that was stated.
By their numbers in this assay, from the lowest: compounds 1, 2 and 3 (each within the scatter of the next).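

In this assay, the phenyl to 4-methylphenyl difference gives a 1.2-fold higher number from compound 2 to compound 3 (0.08 log units; within the scatter), so compound 2 and compound 3 cannot be told apart on this read-out. Among these compounds, this is the first reading on the aryl group of the series, as the earlier step concerned the substituent on the ring amine nitrogen: at this aromatic carbon, para to a large group, a single methyl in place of hydrogen leaves the number within the scatter, just as the phenyl step did at its own site. No measured information is available that would account for the size of this step.

What the compounds shown leave open is whether anything other than methyl at this aromatic carbon, such as a methoxy group, a chlorine atom, an amine or a carboxylic acid, would give a step beyond the scatter in this assay. Also open, from the compounds shown here alone, is whether a methyl on another carbon of this six-membered aromatic ring, or a longer chain in its place, would read the same way as in compound 3.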